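Para substituent on the aryl group: methyl to methoxy

The source may hold more compounds than are shown below. What is called first, only, known or untested is meant among the compounds shown, and "the series" means these compounds.

Going by the values given here, compound 2 `Cc1ccc(-n2cc(NC(=O)c3ccc(NS(=O)(=O)c4ccccc4)cc3)cn2)cc1` gives the lowest of the two numbers so far: in a functional assay on HeLa cells (Homo sapiens) for inhibition, read by MTT assay, with a stated time of 48 h (on this read-out lower numbers stand for stronger inhibition and higher numbers for weaker inhibition), compound 2 gives 27900 nM. Its nearest neighbour is compound 1 `Cn1cc(NC(=O)c2ccc(NS(=O)(=O)c3ccccc3)cc2)cn1`, which in this assay gives 92800 nM. Among the compounds with values here, the one measured step, a 3.3-fold lower number from compound 1 to compound 2 (0.52 log units; beyond the scatter), came from putting 4-methylphenyl in place of methyl on an aromatic nitrogen.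

Compound 3 `COc1ccc(-n2cc(NC(=O)c3ccc(NS(=O)(=O)c4ccccc4)cc3)cn2)cc1` differs from compound 2 only on that aryl group: methoxy in place of methyl on an aromatic carbon. Within the data shown here, no measured step touches this position; the step from compound 1 to compound 2 concerns the substituent on the nitrogen as a whole, not what sits on its ring. With nothing to point either way, the expectation for this assay is a step of a 1.1-fold lower number from compound 2 to compound 3 (0.05 log units; within the scatter), within the scatter. Compound 3 is therefore estimated at 25000 nM, with a range from 9000 nM to 80000 nM.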

Compound 3, half-maximal inhibitory concentration: 47200 nM
Compound 3: middle estimate off by 1.9-fold (0.28 log units), on the low side; the measured number falls inside the stated range.
By their numbers in this assay, from the lowest: compounds 2, 3 and 1 (each within the scatter of the next, the first and the last beyond it).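

At this place, on an aromatic carbon para to a large group, methoxy in place of methyl gives a 1.7-fold higher number from compound 2 to compound 3 (0.23 log units; within the scatter) in this assay, so the two groups cannot be told apart here. The aryl group on the aromatic nitrogen now also reads less clearly: 4-methoxyphenyl gives a 2.0-fold lower number from compound 1 to compound 3 (0.29 log units; within the scatter), whereas 4-methylphenyl gave a 3.3-fold lower number from compound 1 to compound 2 (0.52 log units; beyond the scatter), so a step beyond the scatter is seen with only one of the two aryl groups. No measurement on hand gives a reason for these numbers.

Open, going by these compounds, is how an amine, a carboxylic acid or a chlorine at this same place would read against methyl and methoxy. Also open, on these data alone, is whether a plain phenyl on the aromatic nitrogen would fall nearer compound 1 or compound 2.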